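A few compounds are considered here, and "the series" means these few. Any claim that something is new, unique, unknown or untested is made for them only; others in the source may bear on it.

Working notes on the series. In a functional assay on U-937 cells (Homo sapiens) for cytotoxicity, read by MTT assay, with a stated time of 48 h (on this read-out higher numbers stand for weaker inhibition and lower numbers for stronger inhibition), compound 1 (`COc1c(-c2ccccc2)c2ccccc2n(Cc2ccc(C(=O)NO)cc2)c1=O`) gives "not determined" (no result reported), so it offers no comparison. In this assay compound 2 (`CCN(CC)Cc1ccc(Cn2c(=O)c(OCc3ccc(C(=O)NO)cc3)c(-c3ccccc3)c3ccccc32)cc1`) gives 40600 nM. Among the compounds with values here, this is the only number available, so compound 2 cannot be ranked and serves only as the reference point.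

Compound 3 (`CCN(CC)Cc1ccc(Cn2c(=O)c(OCc3ccc(C(=O)NO)cc3)c(-c3cccnc3)c3ccccc32)cc1`) differs from compound 2 in one place: pyridin-3-yl in place of phenyl on an aromatic carbon, ortho to a (4-(hydroxycarbamoyl)benzyl)oxy group and opposite the ring nitrogen (pyridin-3-yl in place of phenyl on an aromatic carbon). Within the data shown here, no measured pair shows the effect of such a swap, so no change beyond the usual scatter is expected, and no direction can be favoured.

The estimated step is a 1.3-fold lower number from compound 2 to compound 3 (0.10 log units; within the scatter). The expected value for compound 3 is 32000 nM. The estimated range for compound 3 runs from 10000 nM to 85000 nM.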

Compound 3, half-maximal inhibitory concentration: 45500 nM
For compound 3 the middle estimate is 1.4-fold (0.15 log units) below the measured one; measured number inside the range.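

In this assay, pyridin-3-yl in place of phenyl on this aromatic carbon, opposite the ring nitrogen, gives a 1.1-fold higher number from compound 2 to compound 3 (0.05 log units; within the scatter). Within the data shown here, this is the first readable pair at this position: with one ring carbon exchanged for nitrogen and one hydrogen-bond acceptor added, the values of the two compounds cannot be told apart, though this rests on a single pair. No supporting data bear on this result.

Still open, as far as these compounds go, is whether pyridin-2-yl or pyridin-4-yl at the same carbon would read like pyridin-3-yl. From the compounds shown here alone, it is equally open whether a substituted phenyl carrying an amine or a carboxylic acid, or a non-aromatic group such as a longer alkyl chain in place of the ring, would move the number beyond the scatter.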